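This account rests on a few compounds, and the source may have more. Where it says the series, first, only, none or still open, it means among the compounds named here.

Measured so far in the series:

compound 1, `CCCCCCC(=O)NCC(C)(C)CC1=C(O)C(=O)c2ccccc2C1=O`: 28200 nM
compound 2, `CCCCCCCC(=O)NCC(C)(C)CC1=C(O)C(=O)c2ccccc2C1=O`: 24600 nM
compound 3, `CCCCCCCCCCC(=O)OCC(C)(C)CC1=C(O)C(=O)c2ccccc2C1=O`: 54800 nM

All three numbers come from a functional assay on KB cells (Homo sapiens) for cytotoxicity, read by resazurin assay, with a stated time of 3 days; a lower number here means a stronger inhibitor, a higher number a weaker inhibitor. The change from compound 1 to compound 2 is methyl in place of hydrogen on a saturated chain carbon, six bonds along the chain from a carbonyl carbon; the step it made, a 1.1-fold lower number from compound 1 to compound 2 (0.06 log units; within the scatter), is small. Compound 3 has a different core; the difference between the core of compound 1 and the core of compound 3 is not broken down here, so the two values of compound 1 and compound 3 can only be set side by side, and they are within the scatter of each other.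

Compound 4, `CCCCCCCCCCCC(=O)OCC(C)(C)CC1=C(O)C(=O)c2ccccc2C1=O`, has not yet been measured in this assay. It differs from compound 3 by methyl in place of hydrogen on a saturated chain carbon, ten or more bonds along the chain from a carbonyl carbon. Among the compounds with values here, this is the same kind of change as the one from compound 1 to compound 2, not the same change: the place along the chain differs, as the two differences written out above each show in their own words.

The step from compound 3 to compound 4 is expected to be small, a 1.1-fold lower number from compound 3 to compound 4 (0.04 log units; within the scatter), resting on the size of a 1.1-fold lower number from compound 1 to compound 2 (0.06 log units; within the scatter) and on nothing else in the series. Compound 4 is thus expected near 50000 nM, with the likely range from 25000 nM to 100000 nM.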

Compound 4, half-maximal inhibitory concentration: 35700 nM
Compound 4: the middle estimate sits 1.4-fold (0.15 log units) above what was measured; the measured number falls inside the stated range.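

In this assay, methyl in place of hydrogen on a saturated chain carbon, ten or more bonds along the chain from a carbonyl carbon, gives a 1.5-fold lower number from compound 3 to compound 4 (0.19 log units; within the scatter), so the step remains small on this second core. Set beside the earlier step, the change carries from one core to the other with no difference that can be read: the same change on two cores in this assay, a 1.1-fold lower number (0.06 log units; within the scatter) from compound 1 to compound 2 and a 1.5-fold lower number (0.19 log units; within the scatter) from compound 3 to compound 4, 1.3-fold (0.13 log units) apart, within the scatter of two such steps. This does not show that the two steps are equal or that the core has no bearing on the change, as both steps lie within the scatter, the place along the chain differs between them, and two pairs cannot separate the core from that place.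

The compounds shown leave open whether a much longer chain or a branched chain would give a step beyond the scatter. They also leave open what an amine or a carboxylic acid at the chain end would do on either core.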